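Working notes: methoxy for bromo in a three-compound series

The source may report more compounds than this note shows. Statements on the series, on what has been measured and on what is new or still open speak of the compounds shown alone.

Measured in a functional assay on the whole organism (strain albino) for inhibition, with Rattus norvegicus as the target, read by paw edema, with a stated time of 120 min, at a dose of 100 mg/kg by the oral route; a higher number here means more inhibition at the dose given (going by the name of the read-out), a lower number less inhibition:
compound 1 `Clc1ccccc1NCc1nc2ccc(Br)cc2[nH]1` gives 23.5%
compound 2 `Brc1ccc(NCc2nc3ccc(Br)cc3[nH]2)cc1` gives 23.5%
compound 3 `O=[N+]([O-])c1ccc2nc(CNc3ccc(Br)cc3)[nH]c2c1` gives 23.5%

Compound 2 stands level with compound 1 and compound 3: all three values agree within the scatter, the nearest being compound 1 and the furthest compound 3, neither of them differing from compound 2 beyond the scatter. For the measured compounds named here, the one single-point step that is known, no change at the digits printed from compound 2 to compound 3 (within the scatter), changes nothing in this assay.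

Compound 4 `COc1ccc(NCc2nc3ccc(Br)cc3[nH]2)cc1` is not yet measured. It differs from compound 2 as follows: methoxy in place of bromo on an aromatic carbon. Going by the values given here, the only measured step that bears on it is the one from compound 2 to compound 3, likewise a replacement of bromo on an aromatic carbon, and that step was flat. Among the compounds with values here, a methoxy entering in this way has no precedent among the measured compounds.

With one flat step of this kind and all three measured compounds at the same level, no step beyond the scatter is expected; no change at the digits printed from compound 2 to compound 4 (within the scatter) is the expected step. Compound 4 is therefore estimated at 23.5%, with a range from 10% to 38%.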

Compound 4, a percentage reported as inhibition, in the whole organism at one dose (the size of the read-out at that dose, not a potency): 17.6%
Compound 4: middle estimate off by 5.9 percentage points, on the high side, within the range that was stated.
By their numbers in this assay, from the lowest: compounds 4, 1, 2 and 3 (each within the scatter of the next).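

In this assay, methoxy in place of bromo on the aromatic carbon para to a large group gives a number 5.9 percentage points lower from compound 2 to compound 4 (within the scatter). For the compounds shown here, the earlier step replaced the other bromo of compound 2, the one compound 4 keeps, so this is the first reading at this place, and compound 3 still carries the bromo that compound 4 loses. Each of the two bromo groups of compound 2 has now been replaced once, and neither replacement gives a step beyond the scatter, so neither bromo is shown to be needed for the level seen at this single dose; no measured property of these compounds bears on the result.

What the compounds shown leave open is whether any group at this place can move the paw edema read-out beyond the scatter, since methoxy is the only replacement here and one step cannot define a trend. An amine or a carboxylic acid on this aromatic carbon, or a longer chain such as ethoxy or propoxy in place of methoxy, would test that, as would the same groups in place of the bromo on the shared core.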